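Cytotoxicity in Huh-7 cells: from nitro to dimethyl aryl

This account rests on a few compounds, and the source may have more. Where it says the series, first, only, none or still open, it means among the compounds named here.

Compounds measured so far in an ADME assay on Huh-7 cells (Homo sapiens) for cytotoxicity; on this read-out higher numbers stand for lower toxicity in this test and lower numbers for higher toxicity in this test:
- compound 1, `Cc1ccccc1-c1nn(-c2ccc(Cl)cc2)cc1CNCCN1CCN(C)CC1`: 17000 nM
- compound 2, `Cc1ccccc1-c1nn(-c2ccc(Br)cc2)cc1CNCCN1CCN(C)CC1`: 9600 nM
- compound 3, `Cc1ccccc1-c1nn(-c2ccc([N+](=O)[O-])cc2)cc1CNCCN1CCN(C)CC1`: > 20000 nM

Compound 3 stands at the limit of > 20000 nM in this assay, at which 1 of the 3 values shown sits, so for it only a limit is known and no number. Compound 4, `Cc1ccc(-n2cc(CNCCN3CCN(C)CC3)c(-c3ccccc3C)n2)c(C)c1`, differs from compound 3 in one place: 2,4-dimethylphenyl in place of 4-nitrophenyl on an aromatic nitrogen. Among the compounds with values here, none of the measured steps covers this change; they concern chloro, bromo and nitro on the same aromatic carbon. From compound 1 to compound 2 the step was a 1.8-fold lower number from compound 1 to compound 2 (0.25 log units; within the scatter). From compound 1 to compound 3 it was an at least 1.1-fold higher number from compound 1 to compound 3 (0.07 log units; that floor lies within the scatter), and from compound 2 to compound 3 an at least 2.0-fold higher number from compound 2 to compound 3 (0.31 log units; beyond the scatter). The halogen-bearing compounds 1 and 2 gave numbers, while compound 3 reached the limit. A 2,4-dimethylphenyl group is expected to bring compound 4 back towards the numbers of compounds 1 and 2, a step of an at least 1.6-fold lower number from compound 3 to compound 4 (0.22 log units; that floor lies within the scatter) relative to the limit. Compound 4 is therefore estimated at 12000 nM, with a range from 5000 nM to 25000 nM.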

Compound 4, half-maximal cytotoxic concentration: > 20000 nM
Compound 4: only a limit was reported (the forecaster's own chance of this, stated with the estimate: 25%); middle value at least 1.6-fold (0.22 log units) from the limit.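

In this assay, within the data shown here, compound 4 gives > 20000 nM, which is a limit of the assay and not a number, so 4-nitrophenyl is not the only group on this aromatic nitrogen that reaches the limit. 2,4-Dimethylphenyl in place of 4-bromophenyl gives an at least 2.0-fold higher number from compound 2 to compound 4 (0.31 log units; beyond the scatter), and in place of 4-chlorophenyl it gives an at least 1.1-fold higher number from compound 1 to compound 4 (0.07 log units; that floor lies within the scatter). The step between the two compounds without numbers cannot be read because both stand at the limit: the limit of > 20000 nM in this assay, at which 2 of the 4 values shown sit.

Going by these compounds, what numbers compound 3 and compound 4 would give stays open, and so does their order. On these data alone, it is also open whether an amine or a carboxylic acid on the phenyl ring at this aromatic nitrogen would stay at the limit or return a number.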